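This account rests on a few compounds, and the source may have more. Where it says the series, first, only, none or still open, it means among the compounds named here.

Measured so far:
compound 1 `O=C(NCc1ccc(F)cc1)c1ccc(N2CCN(S(=O)(=O)c3ccccc3C(F)(F)F)CC2)nn1`; in an ADME assay on microsomes from liver (Mus musculus) for metabolic stability, read by LC-MS, using NADPH, tested at 10 uM (on this read-out lower numbers stand for a shorter-lived compound and higher numbers for a longer-lived compound), compound 1 gives 0.517 h
compound 2 `Cc1ccccc1S(=O)(=O)N1CCN(c2ccc(C(=O)NCc3cncs3)nn2)CC1`; in this assay compound 2 gives 0.3 h

Compound 1 holds the higher of the two half-life numbers recorded in this assay. Among the measured compounds shown here, compound 2, the nearest, sits close to it and the gap between them lies within the usual scatter of the read-out, so the two values show no order between the compounds. For the measured compounds named here, compounds 1 and 2 differ in more than one place, and no single step between them is computed.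

Compound 3 `Cc1ncccc1S(=O)(=O)N1CCN(c2ccc(C(=O)NCc3ccc(F)cc3)nn2)CC1` is not yet measured. It differs from compound 1 at the sulfonyl sulfur only: 2-methylpyridin-3-yl in place of 2-(trifluoromethyl)phenyl on a sulfonyl sulfur. Going by the values given here, the group on the sulfonyl sulfur is the only part that changes; the shared core and the amide side of compound 1 are kept.

Among the compounds with values here, no measured step on this group exists in the set, so the expectation rests only on the spread of the two numbers recorded. For compound 3 a half-life near the two recorded values is expected, and the step of a 1.3-fold lower number from compound 1 to compound 3 (0.11 log units; within the scatter) is estimated to fall within the scatter, with no firm direction. The estimate for compound 3 is 0.4 h, with a range from 0.2 h to 0.8 h.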

Compound 3, half-life: 0.133 h
Beside the measured number, compound 3's estimate is 3.0-fold (0.48 log units) above it; measured number below the stated range.
By their numbers in this assay, from the lowest: compound 3; then compounds 2 and 1 (each within the scatter of the next).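

The group on the sulfonyl sulfur is not a silent position in this assay: with the shared core and the amide side of compound 1 kept, 2-methylpyridin-3-yl in place of 2-(trifluoromethyl)phenyl gives a 3.9-fold lower number from compound 1 to compound 3 (0.59 log units; beyond the scatter). Among the compounds shown here, this is the first step that can be read at a single place, since the earlier pair differed in more than one place and showed no order. No measurement at hand explains the step, so it can be tied only to the exchange of the whole group and not to any one feature of either group.

The exchange replaces the aromatic ring and its substituent together, so the compounds shown do not separate the ring nitrogen from the change of trifluoromethyl to methyl; a 2-(trifluoromethyl)pyridin-3-yl group on the sulfonyl sulfur would address that directly. Going by these compounds, it also stays open whether a step of this size carries over to other amide sides, as this single pair shares one amide side and gives no second reading of the same exchange.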